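The compounds below may be only part of what the source reports. "The series", "measured", "known", "first", "only" and "open" are said of these compounds alone.

Measured compounds:
compound 1, `CCCOC(=O)C1=C(C)NC(=O)NC1c1cccs1`: 32%
compound 2, `CCC(CC)OC(=O)C1=C(C)NC(=O)NC1c1cccs1`: 1%

In an assay on membranes from HeLa cells for displacement of a labelled ligand from adenosine receptor A3 (Homo sapiens), read by scintillation counting, with a stated time of 180 min, tested at 1 uM (on this read-out higher numbers stand for more inhibition at the one concentration tested (going by the name of the read-out) and lower numbers for less inhibition), compound 2 gives the lower of the two numbers; compound 1 stands a number 31 percentage points lower from compound 1 to compound 2 (beyond the scatter) apart, a large step that came with ethyl in place of hydrogen on a saturated chain carbon bound to an oxygen next to a carbonyl group and a saturated chain carbon. Compound 3, `CC1=C(C(=O)OC2CCCC2)C(c2cccs2)NC(=O)N1`, is not yet measured in this assay. It differs from compound 2 by cyclopentyl in place of pentan-3-yl on an oxygen next to a carbonyl group. Among the measured compounds shown here, no measured step closes a chain into a ring, so the only step that bears on it is the one from compound 1 to compound 2, and it bears only loosely: the two groups hold the same count of carbons, and the ring merely ties the chain ends together. A step of a number 9 percentage points higher from compound 2 to compound 3 (within the scatter) is therefore expected, small or within the scatter, leaning upward at most. Compound 3 is estimated at 10%, with a range from -8% to 30%.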

Compound 3, a percentage reported as inhibition, at one concentration (the size of the read-out at that concentration, not a potency): 1%
Beside the measured number, compound 3's estimate is 9 percentage points above it; the range from low to high includes it.
By their numbers in this assay, from the lowest: compounds 2 and 3 (each within the scatter of the next); then compound 1.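

In this assay, cyclopentyl in place of pentan-3-yl on an oxygen next to a carbonyl group gives no change at the digits printed from compound 2 to compound 3 (within the scatter) and so, at this position, tying the chain ends into a ring makes no readable difference. Starting from propyl, cyclopentyl gives a number 31 percentage points lower from compound 1 to compound 3 (beyond the scatter) and matches the size of a number 31 percentage points lower from compound 1 to compound 2 (beyond the scatter) in this assay, so the large loss does not depend on the group staying an open chain. Nothing measured here explains why either group reads so far under propyl.

From the compounds shown here alone, whether a shorter chain such as ethyl or methyl, or a smaller ring such as cyclobutyl, would read above or under propyl remains open. With only one concentration tested, any difference between pentan-3-yl and cyclopentyl may also lie out of reach of this read-out.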